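The source may report more compounds than this note shows. Statements on the series, on what has been measured and on what is new or still open speak of the compounds shown alone.

Of the compounds shown here, three with a shared core have been tested in a functional assay on HL-60 cells (Homo sapiens) for inhibition, read by MTT assay, with a stated time of 72 h; a lower number here means a stronger inhibitor, a higher number a weaker inhibitor. Compound 1 `CCc1nc(-c2ccccc2F)c(C(=O)N2CCN(c3cccc(Cl)c3)CC2)o1` gives 139 nM. Compound 2 `Cc1ccc(N2CCN(C(=O)c3oc(C)nc3-c3ccccc3)CC2)c(C)c1` gives 101 nM. Compound 3 `COc1cccc(N2CCN(C(=O)c3oc(C(F)(F)F)nc3-c3ccc(F)cc3)CC2)c1` is reported as "not active" (no number reported), with no number given. The values of compound 2 and compound 1 lie within the usual scatter of each other, so neither can be placed ahead of the other; compound 3 stands apart only in that no number was obtained for it.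

Compound 4 `COc1cc(OC)cc(N2CCN(C(=O)c3oc(C)nc3-c3ccccc3)CC2)c1` has not yet been measured. It differs from compound 2 in one place: 3,5-dimethoxyphenyl in place of 2,4-dimethylphenyl on an amine nitrogen in a ring. Compound 3 also carries a methoxy-bearing ring on the same ring nitrogen, but it differs from compound 2 in other places as well, so it cannot show what this change alone does. With no single-change comparison available, the expectation rests on the spread of the two numbers seen. Compound 4 is expected to give 250 nM in this assay, with a range from 80 nM to 900 nM. The step expected is a 2.5-fold higher number from compound 2 to compound 4 (0.39 log units; beyond the scatter), a modest weakening that may not exceed the scatter.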

Compound 4, half-maximal inhibitory concentration: 19.2 nM
Compound 4: the middle estimate sits 13-fold (1.11 log units) above what was measured; measured number outside the range, below it.
By their numbers in this assay, from the lowest: compound 4; then compounds 2 and 1 (each within the scatter of the next).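

On the phenyl ring attached to the ring nitrogen, a single change can now be read in this assay: 3,5-dimethoxyphenyl in place of 2,4-dimethylphenyl gives a 5.3-fold lower number from compound 2 to compound 4 (0.72 log units; beyond the scatter), so the groups on this ring clearly matter. The entering group has 2 hydrogen-bond acceptors and the leaving group 0, but both the type of group and its placement on the ring change in this one step, so these differences cannot be separated. No measurement here gives a reason for the step.

Going by these compounds, it remains open whether a single methoxy group would be enough, or how an amine or a carboxylic acid would compare on this ring. It is also unknown whether the same exchange would have a similar effect on the core of compound 1.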